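Methyl added to the central phenyl of compound 1

A few compounds are considered here, and "the series" means these few. Any claim that something is new, unique, unknown or untested is made for them only; others in the source may bear on it.

Compound 1 `O=C(Nc1ccc(-n2ccc3c(NC(=O)c4ccccc4)nccc32)cc1)Nc1cccc(Cl)c1Cl` is measured in a functional assay on A-375 cells (Homo sapiens) for antiproliferative activity, read by MTT assay, with a stated time of 48 h, in the presence of a further agent that is not named here (on this read-out lower numbers stand for stronger inhibition and higher numbers for weaker inhibition), only as a limit of the assay, > 10000 nM, so its position is known only as the limit of > 10000 nM in this assay, at which 1 of the 2 values shown sits. Going by the values given here, compound 2 `O=C(Nc1ccc(-n2ccc3c(NC(=O)c4ccccc4)nccc32)cc1)Nc1ccc(Cl)c(Cl)c1` gives 200 nM in this assay, and the step of an at least 50-fold lower number from compound 1 to compound 2 (1.69 log units; beyond the scatter) is the single measured step. Compound 3 `Cc1cc(NC(=O)Nc2cccc(Cl)c2Cl)ccc1-n1ccc2c(NC(=O)c3ccccc3)nccc21` keeps the 2,3-dichlorophenyl urea of compound 1 and differs from it by methyl in place of hydrogen on an aromatic carbon. Among the compounds with values here, the measured step concerns the chlorine pattern on the urea aryl ring and does not touch the ring that carries the new methyl, so no measured step bears directly on the change from compound 1 to compound 3; the single-carbon addition gives no basis for expecting a step beyond the scatter, so compound 3 is expected near the limit of compound 1, a step that the limit leaves unreadable from compound 1 to compound 3. For compound 3 the estimate in this assay is 15000 nM, between 5000 nM and 50000 nM, most likely again reported as a limit.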

Compound 3, half-maximal inhibitory concentration: > 10000 nM
Compound 3 ended at the assay's limit; the forecaster's own chance of this, stated with the estimate: 80%; the middle value is on the limit's open side.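

In this assay, going by these compounds alone, compound 3 gives > 10000 nM as a limit of the assay, as compound 1 does, so no step between compound 1 and compound 3 can be read: the limit of > 10000 nM in this assay, at which 2 of the 3 values shown sit.

Still open, as far as these compounds go, is what methyl in place of hydrogen on an aromatic carbon does where the parent compound gives a value that is not a limit.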